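The source may hold more compounds than are shown below. What is called first, only, known or untested is meant among the compounds shown, and "the series" means these compounds.

Of the compounds shown here, three that share one core have been measured in an ADME assay on cells (Hepatocyte, Homo sapiens) for metabolic stability, read by LC-MS, with a stated time of 90 min, tested at 1 uM; on this read-out higher numbers stand for fast clearance and lower numbers for slow clearance. Compound 1 `CNC(=O)c1cc(S(=O)(=O)N2CCS[C@H]2C(=O)O[C@@H](Cc2c(Cl)c[n+]([O-])cc2Cl)c2ccc(OC(F)F)c(OCC3CC3)c2)cn1C` gives 47.6 uL/min. Compound 2 `COc1ccc(S(=O)(=O)N2CCC[C@H]2C(=O)O[C@@H](Cc2c(Cl)c[n+]([O-])cc2Cl)c2ccc(OC(F)F)c(OCC3CC3)c2)cc1C(=O)N(C)C` gives 56.7 uL/min. Compound 3 `Cn1cnc(S(=O)(=O)N2CCS[C@H]2C(=O)O[C@@H](Cc2c(Cl)c[n+]([O-])cc2Cl)c2ccc(OC(F)F)c(OCC3CC3)c2)c1` gives 66.9 uL/min, the highest of the three numbers, yet its gap to compound 2 and its gap to compound 1 both lie within the scatter, so the three compounds cannot be ranked against one another. Compound 4 `COc1ccc(S(=O)(=O)N2CCS[C@H]2C(=O)O[C@@H](Cc2c(Cl)c[n+]([O-])cc2Cl)c2ccc(OC(F)F)c(OCC3CC3)c2)cc1OC` has not yet been measured. It differs from compound 3 in one place: 3,4-dimethoxyphenyl in place of 1-methyl-1H-imidazol-4-yl on a sulfonyl sulfur. Among the measured compounds shown here, the one measured step that bears on this place is a 1.4-fold higher number from compound 1 to compound 3 (0.15 log units; within the scatter), where a larger aromatic group on the sulfonyl sulfur also gave way to the imidazole without a shift beyond the scatter. Compound 2 shows a value close to that of compound 3 as well. Running that kind of exchange the other way, compound 4 is expected to show a 1.1-fold lower number from compound 3 to compound 4 (0.05 log units; within the scatter), that is, nothing beyond the scatter. Compound 4 is therefore estimated at 60 uL/min, with a range from 35 uL/min to 105 uL/min.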

Compound 4, intrinsic clearance in a liver preparation (reported as CLH), per the amount of preparation that the assay uses: 53.8 uL/min
Compound 4: the middle estimate sits 1.1-fold (0.05 log units) above what was measured; low and high end bracket the measured number.
By their numbers in this assay, from the lowest: compounds 1, 4, 2 and 3 (each within the scatter of the next).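

In this assay, this position now has a six-membered carbon ring to compare with the imidazole, and a 1.2-fold lower number from compound 3 to compound 4 (0.09 log units; within the scatter) shows that 3,4-dimethoxyphenyl on the sulfonyl sulfur is not told apart from 1-methyl-1H-imidazol-4-yl. The third group at this place gives the same picture, as a 1.1-fold higher number from compound 1 to compound 4 (0.05 log units; within the scatter) is also within the scatter, so none of the steps among compound 1, compound 3 and compound 4 separates these aromatic groups. Nothing available explains this result.

From the compounds shown here alone, all three groups on the sulfonyl sulfur are aromatic rings, so it remains open whether a group without such a ring, such as a plain butyl chain, would give a number beyond the scatter. The same question stands for an aromatic ring carrying an amine or a carboxylic acid.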